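Carbamate chain length in a selenocyanate series

The source may report more compounds than this note shows. Statements on the series, on what has been measured and on what is new or still open speak of the compounds shown alone.

Compound 1 `C=CCOC(=O)Nc1ccc([Se]C#N)cc1` in a functional assay on HTB-54 cells (Homo sapiens) for cytotoxicity, read by MTT assay, with a stated time of 72 h (a lower number here means a stronger inhibitor of growth, a higher number a weaker inhibitor of growth), gives 27000 nM. Compound 2 `CCOC(=O)Nc1ccc([Se][Se]c2ccc(NC(=O)OCC)cc2)cc1`, the diselenide of the set, in this assay gives 31200 nM; compound 1 and compound 2 sit within the scatter of each other, so neither stands apart. Compound 3 `CCCCCCOC(=O)Nc1ccc([Se]C#N)cc1` is not yet measured; it differs from compound 1 by pentyl in place of vinyl on a saturated chain carbon bound to an oxygen next to a carbonyl group. Nothing measured here carries this change, so the expected step is a 1.4-fold lower number from compound 1 to compound 3 (0.13 log units; within the scatter), small and, if anything, toward a lower number. For compound 3 the expected value in this assay is 20000 nM, with a range from 8000 nM to 50000 nM.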

Compound 3, concentration for 50% growth inhibition: 23600 nM
For compound 3 the middle estimate is 1.2-fold (0.07 log units) below the measured one; the range from low to high includes it.
By their numbers in this assay, from the lowest: compounds 3, 1 and 2 (each within the scatter of the next).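

In this assay, pentyl in place of vinyl on a saturated chain carbon bound to an oxygen next to a carbonyl group gives a 1.1-fold lower number from compound 1 to compound 3 (0.06 log units; within the scatter) as the first step read at this position. Going from allyl to hexyl, with the double bond gone and the chain longer, leaves the two compounds within the scatter of each other. No supporting data bear on this step.

Still open, going by these compounds, is whether a longer chain than hexyl reads the same. An amine or a carboxylic acid in that place is equally untested in the compounds shown.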